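Swapping Cyano for Methyl: What Compound 4 May Give

The source may report more compounds than this note shows. Statements on the series, on what has been measured and on what is new or still open speak of the compounds shown alone.

The measured compounds, with their results in a functional assay on CHO cells for antagonist activity at sphingosine 1-phosphate receptor 2 (Homo sapiens), read by scintillation counting and GTPgammaS binding, with a stated time of 4 h, in the presence of a further agent that is not named here; a lower number here means a stronger inhibitor, a higher number a weaker inhibitor:
Compound 1 `Cc1cc(NNC(=O)Nc2cc(Cl)nc(Cl)c2)ncc1-c1cn(C)nc1C` gives 0.8 nM.
Compound 2 `Cc1cc(NNC(=O)Nc2cc(Cl)nc(Cl)c2)nc(-c2ccc(F)cc2)c1` gives 6.2 nM.
Compound 3 `CCOc1cc(NC(=O)NCc2cc(C)c(-c3cn(C)nc3C(F)(F)F)nn2)cc(C#N)n1` gives 35 nM.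

Of these three, compound 3 has the highest number in this assay, so it is the weakest inhibitor among them. Its distance to compound 2, the nearest of the other two, and its distance to compound 1, the furthest, both lie beyond the scatter of repeated measurements, so its place at the weak end is secure on these numbers.

Compound 4 `CCOc1cc(NC(=O)NCc2cc(C)c(-c3cn(C)nc3C(F)(F)F)nn2)cc(C)n1` differs from compound 3 in a single place: methyl in place of cyano on an aromatic carbon. Among the measured compounds shown here, no pair among the measured compounds shows this same exchange, so there is no measured step to lean on; the three measured compounds differ from one another in several places at once, and only the values themselves can be compared.

With nothing measured to guide the direction, the expectation is a small step, within the scatter, or at most a modest move towards a weaker inhibitor. The step expected here is a 1.3-fold higher number from compound 3 to compound 4 (0.11 log units; within the scatter). For compound 4 the estimate in this assay is 45 nM, with a range from 12 nM to 160 nM.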

Compound 4, half-maximal inhibitory concentration: 242 nM
Estimate against measurement, compound 4: 5.4-fold (0.73 log units) below; measured number outside the range, above it.
By their numbers in this assay, from the lowest: compound 1; then compound 2; then compound 3; then compound 4.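

In this assay, the change from 2-cyano-6-ethoxypyridin-4-yl to 2-ethoxy-6-methylpyridin-4-yl brings a 6.9-fold higher number from compound 3 to compound 4 (0.84 log units; beyond the scatter), and this is the first pair shown that differs in a single place. The rest of the two structures is identical, so the drop in inhibition goes with this one exchange on the aromatic carbon next to the ring nitrogen: the group here clearly matters, and with this ethoxy group and this side of the molecule held constant, cyano gives the stronger inhibitor of the two. Nothing measured here says what lies behind the difference.

A single step with two groups shows neither how other groups would behave at this position, such as a chlorine atom, a methoxy group, an amine or a carboxylic acid, nor where the best choice lies. It also leaves open whether the exchange of cyano for methyl would give a step of similar size if the neighbouring ethoxy group gave way to a longer chain or a hydroxyl group, or if the remainder of the molecule were different.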